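Swapping the aryl group on the amine nitrogen

The compounds below may be only part of what the source reports. "The series", "measured", "known", "first", "only" and "open" are said of these compounds alone.

In a functional assay on CCRF-CEM cells (Homo sapiens) for cytotoxicity, in the absence of a further agent (on this read-out lower numbers stand for stronger inhibition and higher numbers for weaker inhibition), compound 1 (`COC(=O)c1ccc(CN(CCCc2c(N)nc(N)nc2O)c2cc(F)c(F)cc2[N+](=O)[O-])cc1`) gives 55000 nM. Compound 2 (`Nc1nc(N)c(CCCN(Cc2ccc(NC(CCC(=O)O)C(=O)O)cc2)c2cc(F)c(F)cc2[N+](=O)[O-])c(O)n1`) gives > 100000 nM, which is a limit of the assay and not a number. Among the measured compounds shown here, the only measured step, an at least 1.8-fold higher number from compound 1 to compound 2 (0.25 log units; that floor lies within the scatter), puts (1,3-dicarboxypropyl)amino in place of methoxycarbonyl on an aromatic carbon, and its floor lies within the scatter. Compound 2 therefore has no exact position, only the limit of > 100000 nM in this assay, at which 1 of the 2 values shown sits, as its bound.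

Compound 3 (`Nc1nc(N)c(CCCN(Cc2ccc(NC(CCC(=O)O)C(=O)O)cc2)c2ccc([N+](=O)[O-])c(F)c2F)c(O)n1`) carries 2,3-difluoro-4-nitrophenyl in place of 4,5-difluoro-2-nitrophenyl on an amine nitrogen, with the counted difference (2,3-difluoro-4-nitrophenyl in place of 4,5-difluoro-2-nitrophenyl on an amine nitrogen). The measured step concerns another part of the molecule, so it gives no size for this exchange. The expected step is a number no higher from compound 2 to compound 3 (the limit leaves the size open), with no shift beyond the scatter anticipated in this assay. For compound 3 the estimated value is 100000 nM, within an expected range of 40000 nM to 250000 nM.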

Compound 3, half-maximal inhibitory concentration: > 100000 nM
Compound 3 gave a limit, no number (the forecaster's own chance of this, stated with the estimate: 80%); the middle value lies on the limit itself.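

Among the compounds shown here, compound 2 and compound 3 both end at a limit of the assay, not a number, so no step between them can be read in this assay. On these data alone, whether 2,3-difluoro-4-nitrophenyl and 4,5-difluoro-2-nitrophenyl on the amine nitrogen differ at all on this read-out remains open.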